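This account rests on a few compounds, and the source may have more. Where it says the series, first, only, none or still open, it means among the compounds named here.

Three compounds have numbers in a functional assay on HeLa cells (Homo sapiens) for cytotoxicity, read by WST assay, with a stated time of 48 h; a higher number here means a weaker inhibitor, a lower number a stronger inhibitor. Compound 1 `COc1cccc([C@@H]2OC[C@H]([C@@H](O)c3ccc(OC)c(OC)c3)C[C@H]2C/C=C/c2ccc(OC)c(OC)c2)c1` gives 30100 nM, compound 2 `Oc1ccc(/C=C/C[C@H]2C[C@@H]([C@@H](O)c3ccccc3)CO[C@@H]2c2ccccc2)cc1` gives 14400 nM, and compound 3 `COc1cccc(/C=C/C[C@H]2C[C@@H]([C@@H](O)c3ccc(OC)c(OC)c3)CO[C@@H]2c2ccc(OC)c(OC)c2)c1` gives 14000 nM. Compound 2 holds the second highest of these three numbers; its value and that of compound 3 lie within the scatter of each other, while compound 1 gives a higher number than compound 2, a gap beyond the scatter. Compound 4 `O[C@@H](c1ccccc1)[C@H]1CO[C@H](c2ccccc2)[C@@H](C/C=C/c2ccncc2)C1` is not yet measured. It differs from compound 2 in one place: pyridin-4-yl in place of 4-hydroxyphenyl on a double-bonded chain carbon bound to a double-bonded chain carbon. Going by the values given here, no measured pair shows this change, so its size and direction are unknown. Without a measured guide, the expected step is a 1.0-fold higher number from compound 2 to compound 4 (0.02 log units; within the scatter), not beyond the scatter. Compound 4 is estimated at 15000 nM, within a range from 5000 nM to 45000 nM.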

Compound 4, half-maximal inhibitory concentration: > 100000 nM
Compound 4 gave a limit, no number; the forecaster's own chance of this, stated with the estimate: 10%; middle value at least 6.6-fold (0.82 log units) from the limit.
By their numbers in this assay, from the lowest: compounds 3 and 2 (each within the scatter of the next); then compound 1. At a limit, above all of these: compound 4.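

The earlier compounds shown here showed no measured change at this position. Pyridin-4-yl in place of 4-hydroxyphenyl on a double-bonded chain carbon bound to a double-bonded chain carbon gives an at least 6.9-fold higher number from compound 2 to compound 4 (0.84 log units; beyond the scatter), so activity in this cell assay depends on the group held here. For compound 4, this assay returns a limit and not a number: the limit of > 100000 nM in this assay, at which 1 of the 4 values shown sits.

On these data alone, the full size of this step remains unknown, and a single change cannot separate the loss of the hydroxyl from the entry of the ring nitrogen. A 4-aminophenyl group at this place would test whether other ring substituents are tolerated.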